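A few compounds are considered here, and "the series" means these few. Any claim that something is new, unique, unknown or untested is made for them only; others in the source may bear on it.

Compound 2 `COc1cc(-c2nn(-c3cccc(NC(=O)Nc4cccc(C(F)(F)F)c4)c3)cc2-c2ccncc2)ccc1Cl` is one of two compounds tested in a functional assay on SW-620 cells (Homo sapiens) for inhibition, read by sulforhodamine B assay, with a stated time of 48 h; a higher number here means that more compound is tolerated, a lower number that less compound is tolerated. In this assay compound 2 gives 50000 nM, the only plain number shown. Compound 1 `COc1cc(-c2nn(-c3cccc(NC(=O)c4ccc(Cl)c(C(F)(F)F)c4)c3)cc2-c2ccncc2)ccc1Cl` differs from compound 2 in carrying 4-chloro-3-(trifluoromethyl)phenyl rather than (3-(trifluoromethyl)phenyl)amino on the carbonyl carbon; in this assay compound 1 reaches only a limit, > 32500 nM. The step that the limit leaves unreadable from compound 1 to compound 2 therefore cannot be sized, as the limit of > 32500 nM in this assay, at which 1 of the 2 values shown sits, shows. Compound 3 `COc1cc(-c2nn(-c3cccc(NC(=O)Nc4ccc(Cl)c(C(F)(F)F)c4)c3)cc2-c2ccncc2)ccc1Cl` has not yet been measured; it differs from compound 2 by chloro in place of hydrogen on an aromatic carbon. For the measured compounds named here, no measured step isolates this change: the single step from compound 1 to compound 2 alters two things at once and is unreadable. In this assay, then, no shift beyond the usual scatter is expected, and compound 3 is estimated at 45000 nM, within a range from 15000 nM to 100000 nM. The expected step is accordingly a 1.1-fold lower number from compound 2 to compound 3 (0.05 log units; within the scatter).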

Compound 3, concentration lethal to 50% of the cells: > 32500 nM
Compound 3: no number, only a limit; the forecaster's own chance of this, stated with the estimate: 40%; the middle value is on the limit's open side.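

Compound 3 reaches only a limit in this assay, so no step from compound 1 or compound 2 to compound 3 can be read: the limit of > 32500 nM in this assay, at which 2 of the 3 values shown sit.

The compounds shown leave open whether chloro in place of hydrogen, or the amino link on the carbonyl carbon, shifts the lethal concentration at all.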